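The compounds below may be only part of what the source reports. "The series", "measured", "known", "first", "only" and "open" are said of these compounds alone.

Measured compounds:
- compound 1, `CN1CCc2nc(C#Cc3cccnc3)ccc2C1=O`, in a functional assay on HEK293 cells for positive allosteric modulation of metabotropic glutamate receptor 5 (Homo sapiens), read by FLIPR and calcium flux; a higher number here means that more compound is needed for the effect, a lower number that less compound is needed: "not active" (no number reported)
- compound 2, `Cc1cccc(C#Cc2ccc3c(n2)CCN(C2CCCC2)C3=O)c1`, in this assay : 7.5 nM

Compound 1 carries no number; the record for it says only that no activity was found. Compound 2 therefore holds the only number shown, and with a single further entry that reports no value, there is nothing measured to set it against.

Compound 3, `COc1cccc(C#Cc2ccc3c(n2)CCN(C2CCCC2)C3=O)c1`, keeps everything of compound 2 except one group on the outer carbon-only ring, where (methoxy in place of methyl on an aromatic carbon). Going by the values given here, no pair of measured compounds shows what this swap does here, so the expectation rests on the size of the change alone: one group of one heavy atom gives way to one of two heavy atoms in the same place, with one hydrogen-bond acceptor added. For a change this small, the expected step is modest, about a 2.0-fold higher number from compound 2 to compound 3 (0.30 log units; within the scatter), leaning toward needing somewhat more compound but not far beyond the usual scatter. Compound 3 is thus estimated at 15 nM, within a range from 5 nM to 50 nM.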

Compound 3, half-maximal effective concentration: 462 nM
Compound 3: the middle estimate sits 31-fold (1.49 log units) below what was measured; the whole stated range lies below it.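

In this assay, replacing 3-methylphenyl with 3-methoxyphenyl produces a 62-fold higher number from compound 2 to compound 3 (1.79 log units; beyond the scatter) and so shows that this position on the outer carbon-only ring is highly sensitive to the group it carries. Going by these compounds alone, the exchange adds only one heavy atom and one hydrogen-bond acceptor, yet that small difference in the structure is enough to carry the number well beyond the usual scatter, something that the earlier compounds could not reveal, since compound 1 has no number and differs from compound 2 in more than one place. No measured information here bears on the reason, so the size of the step is established while its cause stays unexplained.

The compounds shown leave open whether the oxygen itself or simply the longer group matters, a question that an ethyl group, a chlorine atom or a hydroxyl group on the same carbon could help to separate. They also leave open how a plain phenyl ring with no added group would compare with either compound.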